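Swapping the benzyl substituent: from methyl to chlorine

This account rests on a few compounds, and the source may have more. Where it says the series, first, only, none or still open, it means among the compounds named here.

Compound 1, `Cc1ccc(Cn2cc(COc3ccc4c(=O)ccoc4c3)nn2)cc1`: 10400 nM
Compound 2, `O=c1ccoc2cc(OCc3cn(Cc4cccc(F)c4)nn3)ccc12`: > 100000 nM
Compound 3, `O=c1ccoc2cc(OCc3cn(Cc4ccc(F)cc4)nn3)ccc12`: 11200 nM
Compound 4, `O=c1ccoc2cc(OCc3cn(Cc4cccc(Cl)c4)nn3)ccc12`: not yet measured

Three compounds share one core and differ only in the group hanging from the saturated chain carbon bound to an aromatic nitrogen. In a functional assay on SW480 cells (Homo sapiens) for cytotoxicity, read by MTT assay, with a stated time of 48 h (on this read-out lower numbers stand for stronger inhibition and higher numbers for weaker inhibition), compound 1 gives 10400 nM, the lowest number among the two values recorded as numbers. Compound 3 sits close by, with a 1.1-fold higher number from compound 1 to compound 3 (0.03 log units; within the scatter). Compound 2 reaches only a limit of the assay, (the limit of > 100000 nM in this assay, at which 1 of the 3 values shown sits), so its value is not a number.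

Compound 4 replaces the group of compound 1 as follows: 3-chlorophenyl in place of 4-methylphenyl on a saturated chain carbon bound to an aromatic nitrogen. The closest measured counterpart is compound 2, which carries 3-fluorophenyl; the change from compound 1 to compound 2 gave an at least 9.6-fold higher number from compound 1 to compound 2 (0.98 log units; beyond the scatter), and the reverse move to 4-fluorophenyl gave an at least 8.9-fold lower number from compound 2 to compound 3 (0.95 log units; beyond the scatter). Both point the same way, so compound 4 is expected to give a clearly higher number than compound 1, estimated as a 5.8-fold higher number from compound 1 to compound 4 (0.76 log units; beyond the scatter). Compound 4 is therefore estimated at 60000 nM, between 15000 nM and 250000 nM, with a real chance that only a limit is reported.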

Compound 4, half-maximal inhibitory concentration: 12900 nM
Compound 4: middle estimate off by 4.7-fold (0.67 log units), on the high side; measured number outside the range, below it.
By their numbers in this assay, from the lowest: compounds 1, 3 and 4 (each within the scatter of the next). At a limit, above all of these: compound 2.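

In this assay, 3-chlorophenyl on the saturated chain carbon bound to an aromatic nitrogen does not separate from the earlier active compounds: a 1.2-fold higher number from compound 1 to compound 4 (0.09 log units; within the scatter), and a 1.2-fold higher number from compound 3 to compound 4 (0.06 log units; within the scatter). Among these compounds, the poor result of compound 2 therefore does not carry over to its chlorine counterpart, since the single change of fluoro to chloro on an aromatic carbon gives an at least 7.7-fold lower number from compound 2 to compound 4 (0.88 log units; beyond the scatter). Compound 2 stays at a limit of the assay, so that step has no exact size: the limit of > 100000 nM in this assay, at which 1 of the 4 values shown sits.

Whether compound 2 is a lone exception remains open, as 3-fluorophenyl is the only group shown to stand apart. Also open, as far as these compounds go, is how a benzyl ring carrying a methoxy group, an amine or a carboxylic acid would read, and whether any such group could give a clearly lower number.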